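The source may hold more compounds than are shown below. What is called first, only, known or untested is meant among the compounds shown, and "the series" means these compounds.

Measured in a functional assay on HL-60 cells (Homo sapiens) for cytotoxicity, read by MTT assay, with a stated time of 4 days; a lower number here means a stronger inhibitor, a higher number a weaker inhibitor:
compound 1 `C=C1C[C@]23C[C@@]1(O)CC[C@H]2c1cc(Br)c(O)c(C)c1[C@@H]3Cn1cc(-c2ccc(OC)cc2)nn1` gives > 20000 nM
compound 2 `C=C1C(=O)[C@]23C[C@@]1(O)CC[C@H]2c1ccc(O)c(C)c1[C@@H]3Cn1cc(-c2ccc(C(F)(F)F)cc2)nn1` gives 720 nM
compound 3 `C=C1C(=O)[C@]23C[C@@]1(O)CC[C@H]2c1ccc(O)c(C)c1[C@@H]3Cn1cc(-c2ccc(OC)cc2)nn1` gives 1150 nM

The value for compound 1 is a limit of this assay, not a number. Compound 4 `C=C1C[C@]23C[C@@]1(O)CC[C@H]2c1cc(Br)c(O)c(C)c1[C@@H]3Cn1cc(-c2ccc(C(F)(F)F)cc2)nn1` shares the core of compound 1 and differs from it in one place: trifluoromethyl in place of methoxy on an aromatic carbon. Going by the values given here, the only measured step of this kind runs the other way, a 1.6-fold higher number from compound 2 to compound 3 (0.20 log units; within the scatter), a change within the scatter. Turned around, it suggests that swapping methoxy for trifluoromethyl moves this assay little in either direction, so compound 4 is expected to remain near (the limit of > 20000 nM in this assay, at which 1 of the 3 values shown sits). The estimate for compound 4 is 30000 nM, with a range from 10000 nM to 100000 nM. The expected step is a step that the limit leaves unreadable from compound 1 to compound 4, which is no real change.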

Compound 4, half-maximal inhibitory concentration: 7380 nM
The estimate for compound 4 lay 4.1-fold (0.61 log units) above the measured number; the whole stated range lies above it.
By their numbers in this assay, from the lowest: compounds 2 and 3 (each within the scatter of the next); then compound 4. At a limit, above all of these: compound 1.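

On the core of compound 1, putting trifluoromethyl in place of methoxy at this position does register in this assay, as an at least 2.7-fold lower number from compound 1 to compound 4 (0.43 log units; beyond the scatter). The same swap on the other core stayed within the scatter, so a change that looked silent there is not silent on every core. Whether the two cores truly respond differently remains unsettled: the same change on two cores in this assay, a 1.6-fold higher number (0.20 log units; within the scatter) from compound 2 to compound 3 and an at least 2.7-fold higher number (0.43 log units; beyond the scatter) from compound 4 to compound 1; the limit leaves it open whether they differ

The compounds shown leave open how an amine or a carboxylic acid in this same place would read.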